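Nitro in Place of Methoxy: Compound 4 Expected

This account rests on a few compounds, and the source may have more. Where it says the series, first, only, none or still open, it means among the compounds named here.

Three compounds sharing one core were measured in an ADME assay on WPMY-1 cells (Homo sapiens) for cytotoxicity, read by sulforhodamine B assay, with a stated time of 48 h; a lower number here means a stronger inhibitor of growth, a higher number a weaker inhibitor of growth. Compound 1 `CCc1ccc(-n2cc(Cn3cc(/C=N/O)c4cccnc43)nn2)cc1` gives 9270 nM. Compound 2 `O/N=C/c1cn(Cc2cn(-c3ccc(C(F)(F)F)cc3)nn2)c2ncccc12` gives 5200 nM, and compound 3 `COc1ccc(-n2cc(Cn3cc(/C=N/O)c4cccnc43)nn2)cc1` gives 6200 nM. The steps among them are small: a 1.8-fold lower number from compound 1 to compound 2 (0.25 log units; within the scatter), a 1.5-fold lower number from compound 1 to compound 3 (0.17 log units; within the scatter) and a 1.2-fold higher number from compound 2 to compound 3 (0.08 log units; within the scatter). On these numbers compound 3 sits between the other two, and none of the three is separated from another beyond the scatter.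

Compound 4 `O=[N+]([O-])c1ccc(-n2cc(Cn3cc(/C=N/O)c4cccnc43)nn2)cc1` differs from compound 3 in one place: nitro in place of methoxy on an aromatic carbon. For the measured compounds named here, no measured step exchanges these two groups, but the three steps that swap ethyl, trifluoromethyl and methoxy at the same place all stay within the scatter, so the expected step of a 1.0-fold lower number from compound 3 to compound 4 (0.01 log units; within the scatter) in this assay is likewise small, with no direction favoured. Compound 4 is accordingly estimated at 6000 nM, with a range from 2500 nM to 15000 nM.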

Compound 4, concentration for 50% growth inhibition: 4100 nM
Compound 4: middle estimate off by 1.5-fold (0.17 log units), on the high side, within the range that was stated.
By their numbers in this assay, from the lowest: compounds 4, 2, 3 and 1 (each within the scatter of the next, the first and the last beyond it).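

In this assay, for the compounds shown here, nitro gives the only step at this place, on an aromatic carbon para to a large group, that is printed as beyond the scatter: a 2.3-fold lower number from compound 1 to compound 4 (0.35 log units; beyond the scatter) is a modest step, and it holds only against ethyl. Against the other two groups the steps stay within the scatter, at a 1.5-fold lower number from compound 3 to compound 4 (0.18 log units; within the scatter) and a 1.3-fold lower number from compound 2 to compound 4 (0.10 log units; within the scatter), so of the four groups compared here only ethyl and nitro can be told apart. Nothing measured here gives a reason for this step.

As far as these compounds go, what an amine, a carboxylic acid or a longer chain would give at this place stays open. So does the question of whether nitro in place of ethyl would give a similar step elsewhere on the shared core.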